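Halogen swap on the sulfonyl phenyl group

The source may report more compounds than this note shows. Statements on the series, on what has been measured and on what is new or still open speak of the compounds shown alone.

Measured in a functional assay on DLD-1 cells (Homo sapiens) for antiproliferative activity, read by CellTiter-Glo, with a stated time of 72 h; on this read-out lower numbers stand for stronger inhibition and higher numbers for weaker inhibition:
- Compound 1 `CC1CCN(C2CCN(S(=O)(=O)c3ccccc3Br)CC2)CC1`: 3 nM
- Compound 2 `COc1cccc(S(=O)(=O)N2CCC(N3CCC(C)CC3)CC2)c1`: > 5000 nM (a limit of the assay)
- Compound 3 `CC1CCN(C2CCN(S(=O)(=O)c3ccc(Br)c(Cl)c3)CC2)CC1`: 12 nM

Compound 3 holds the higher of the two values that are true numbers. The gap is a 4.0-fold higher number from compound 1 to compound 3 (0.60 log units; beyond the scatter). The value for compound 2 is only a limit.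

Compound 4 `CC1CCN(C2CCN(S(=O)(=O)c3cc(Cl)cc(Cl)c3)CC2)CC1` has not yet been measured. It carries 3,5-dichlorophenyl in place of 4-bromo-3-chlorophenyl on a sulfonyl sulfur.

Going by the values given here, two measured steps bear on this change. Exchanging one bromine-bearing phenyl group for another gave a 4.0-fold higher number from compound 1 to compound 3 (0.60 log units; beyond the scatter), a modest shift. Exchanging 3-methoxyphenyl for a halogen-bearing phenyl group gave an at least 410-fold lower number from compound 2 to compound 3 (2.61 log units; beyond the scatter), a large one. Compound 4 keeps chlorine but loses the bromine found in both compounds with numeric values, so a modest rise is expected, with a real risk of a larger one. The expected change is a 3.3-fold higher number from compound 3 to compound 4 (0.52 log units; beyond the scatter). For compound 4 the estimate is 40 nM, with an expected range of 8 nM to 400 nM.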

Compound 4, half-maximal inhibitory concentration: 3400 nM
Estimate against measurement, compound 4: 85-fold (1.93 log units) below; the whole stated range lies below it.
By their numbers in this assay, from the lowest: compound 1; then compound 3; then compound 4. At a limit, above all of these: compound 2.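

Exchanging 4-bromo-3-chlorophenyl for 3,5-dichlorophenyl gave a 280-fold higher number from compound 3 to compound 4 (2.45 log units; beyond the scatter), and the exchange from 2-bromophenyl gave a 1100-fold higher number from compound 1 to compound 4 (3.05 log units; beyond the scatter), so chlorine on the phenyl group on the sulfonyl sulfur does not by itself keep the low numbers, which here belong only to the two bromine-bearing compounds, compound 1 and compound 3. Measured against the 3-methoxyphenyl group, the change gave an at least 1.4-fold lower number from compound 2 to compound 4 (0.16 log units; that floor lies within the scatter), so the halogen-bearing compound 4 is not clearly separated from compound 2. Compound 2 is known only as a limit: the limit of > 5000 nM in this assay, at which 1 of the 4 values shown sits.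

The compounds shown leave open whether bromine itself accounts for the gap, since a 3,5-dibromophenyl group does not appear among them. They also leave open how a trifluoromethyl or nitrile group would behave on this phenyl ring.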